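From 4-chloro-3-fluorophenyl to 3-chlorophenyl in growth inhibition

A few compounds are considered here, and "the series" means these few. Any claim that something is new, unique, unknown or untested is made for them only; others in the source may bear on it.

Of the compounds shown here, three sharing one core have been measured in a functional assay on UO-31 cells (Homo sapiens) for inhibition, read by sulforhodamine B assay, with a stated time of 48 h; a lower number here means a stronger inhibitor of growth, a higher number a weaker inhibitor of growth. Compound 1 (`CN1CCN(CCCOc2cccc3nc(Nc4ccc(Cl)c(C(F)(F)F)c4)ccc23)CC1`) gives 1460 nM, compound 2 (`CN1CCN(CCCOc2cccc3nc(Nc4ccc(Cl)c(F)c4)ccc23)CC1`) gives 1570 nM and compound 3 (`CN1CCN(CCCOc2cccc3nc(Nc4ccc(F)c(F)c4)ccc23)CC1`) gives 4340 nM. Compound 2 therefore cannot be separated from compound 1, as the record shows a 1.1-fold higher number from compound 1 to compound 2 (0.03 log units; within the scatter). Compound 3 stands apart from both, with a 3.0-fold higher number from compound 1 to compound 3 (0.47 log units; beyond the scatter) and a 2.8-fold higher number from compound 2 to compound 3 (0.44 log units; beyond the scatter).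

Compound 4 (`CN1CCN(CCCOc2cccc3nc(Nc4cccc(Cl)c4)ccc23)CC1`) is the next compound to follow from compound 2. The change is 3-chlorophenyl in place of 4-chloro-3-fluorophenyl on a nitrogen on an aromatic ring. Within the data shown here, no measured step makes this exact change, so the evidence is indirect. Among the measured compounds shown here, two steps bear on it. The replacement of trifluoromethyl by fluoro gave a 1.1-fold higher number from compound 1 to compound 2 (0.03 log units; within the scatter), which suggests some tolerance for change on this ring. The replacement of chloro by fluoro gave a 2.8-fold higher number from compound 2 to compound 3 (0.44 log units; beyond the scatter), which shows that a modest change is also possible there.

A small move towards a higher number in this assay is therefore expected, namely a 1.7-fold higher number from compound 2 to compound 4 (0.22 log units; within the scatter). For compound 4 the estimated value is 2600 nM, with an expected range from 1100 nM to 6000 nM.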

Compound 4, concentration for 50% growth inhibition: 1840 nM
Compound 4: middle estimate off by 1.4-fold (0.15 log units), on the high side; measured number inside the range.
By their numbers in this assay, from the lowest: compounds 1, 2 and 4 (each within the scatter of the next); then compound 3.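

In this assay, removing the fluoro group from the 4-chloro-3-fluorophenyl ring leaves the number within the scatter (a 1.2-fold higher number from compound 2 to compound 4 (0.07 log units; within the scatter)), and replacing 4-chloro-3-(trifluoromethyl)phenyl with 3-chlorophenyl does the same (a 1.3-fold higher number from compound 1 to compound 4 (0.10 log units; within the scatter)). The earlier compounds shown here showed that trifluoromethyl and fluoro could be exchanged at this ring without a separable change, and compound 4 now shows that the second substituent can be absent altogether. The step from 3,4-difluorophenyl to 3-chlorophenyl lies beyond the scatter (a 2.4-fold lower number from compound 3 to compound 4 (0.37 log units; beyond the scatter)), so among these four compounds, the three carrying a chloro group sit together, while compound 3, which has none, stands apart, and no compound shown goes against this. Nothing shown explains why these rings fall as they do.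

As far as these compounds go, whether the chloro group itself is needed remains open, and an unsubstituted phenyl, or a nitrile or methoxy group in its place, would address that. The compounds shown also leave open whether a bromo group would sit with the chloro compounds or with compound 3.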